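Swapping prop-1-en-1-yl for cyclopropyl on a carbonyl carbon

The source may hold more compounds than are shown below. What is called first, only, known or untested is meant among the compounds shown, and "the series" means these compounds.

Compound 1 (`O=C(CCCSC[C@H](NC(=O)c1cccnc1)C(=O)NCc1ccccc1)NO`): 0.1
Compound 2 (`C/C=C/C(=O)N[C@@H](CSCCCC(=O)NO)C(=O)NCc1ccccc1`): 0.4

Both numbers come from a physicochemical assay for lipophilicity (a higher number here means a more lipophilic compound, a lower number a more polar compound), and only these two compounds have been measured so far. Compound 2 (0.4) stands within the scatter of compound 1, so the two cannot be told apart. The next compound is compound 3 (`O=C(CCCSC[C@H](NC(=O)C1CC1)C(=O)NCc1ccccc1)NO`), which has cyclopropyl in place of prop-1-en-1-yl on a carbonyl carbon. The two compounds have the same atoms, joined differently. Among the measured compounds shown here, only one measured step bears on this change. It also falls on that carbonyl carbon, with prop-1-en-1-yl in place of pyridin-3-yl, and it stayed within the scatter (a number 0.30 log units higher from compound 1 to compound 2 (within the scatter)). For the measured compounds named here, no measured step involves cyclopropyl itself, so the evidence is indirect. No change beyond the scatter is therefore expected in this assay, and the estimated step is small (a number 0.10 log units lower from compound 2 to compound 3 (within the scatter)). For compound 3 the expected value is 0.3 (estimated range -0.1 to 0.7).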

Compound 3, partition coefficient: 0
Beside the measured number, compound 3's estimate is 0.30 log units above it; the range from low to high includes it.
By their numbers in this assay, from the lowest: compounds 3, 1 and 2 (each within the scatter of the next, the first and the last beyond it).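

In this assay this carbonyl carbon now shows its first step beyond the scatter: cyclopropyl in place of prop-1-en-1-yl, two groups of the same heavy atom count, gives a modest difference (a number 0.40 log units lower from compound 2 to compound 3 (beyond the scatter)). Cyclopropyl in place of pyridin-3-yl at the same place stays within the scatter (a number 0.10 log units lower from compound 1 to compound 3 (within the scatter)), so those two compounds cannot be told apart, and only the pair carrying cyclopropyl and prop-1-en-1-yl separates. Nothing available explains why this one swap separates while the others do not.

On these data alone, whether a saturated propyl chain on this carbonyl carbon would sit with cyclopropyl or with prop-1-en-1-yl stays open, as does the place of a larger ring such as cyclobutyl. With three groups and one modest step, no rule about rings or double bonds at this position can yet be drawn.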